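From 3-hydroxypropoxy to allyloxy on the shared core

The source may report more compounds than this note shows. Statements on the series, on what has been measured and on what is new or still open speak of the compounds shown alone.

Three compounds of the series have values in a functional assay on U-937 cells (Homo sapiens) for cytotoxicity, read by MTT assay, with a stated time of 24 h; on this read-out lower numbers stand for stronger inhibition and higher numbers for weaker inhibition. Compound 1 (`CC(C)(C)OC(=O)N1CCCN(CCCCCOc2c(Br)cc(Br)cc2Oc2ccc(Br)cc2Br)CC1`) gives 39.5 ug/mL, compound 2 (`Brc1ccc(Oc2cc(Br)cc(Br)c2OCCCCCN2CCN(c3ccccc3)CC2)c(Br)c1`) gives 42.5 ug/mL and compound 3 (`OCCCOc1c(Br)cc(Br)cc1Oc1ccc(Br)cc1Br`) gives 32.3 ug/mL. Compound 3 stands within the scatter of both other compounds, so these three numbers do not separate, although the groups on the chain differ widely.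

The next compound, compound 4 (`C=CCOc1c(Br)cc(Br)cc1Oc1ccc(Br)cc1Br`), carries vinyl in place of 2-hydroxyethyl on a saturated chain carbon bound to an oxygen on an aromatic ring. The same difference reads 3-hydroxypropoxy to allyloxy: vinyl in place of 2-hydroxyethyl on a saturated chain carbon bound to an oxygen on an aromatic ring. Among the measured compounds shown here, no pair of measured compounds differs in one place only, so the series offers no direct precedent for the size of this change.

The expectation rests on the narrow spread of the measured compounds: compound 3 at 32.3 ug/mL cannot be told apart from compound 2 at 42.5 ug/mL, despite their very different chains. The expected step in this assay is a 1.1-fold higher number from compound 3 to compound 4 (0.03 log units; within the scatter), which means no move beyond the scatter and no firm direction. For compound 4 the estimated value is 35 ug/mL, with an expected range of 18 ug/mL to 65 ug/mL.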

Compound 4, half-maximal inhibitory concentration: 29 ug/mL
The estimate for compound 4 lay 1.2-fold (0.08 log units) above the measured number, and the stated range covers the measured number.
By their numbers in this assay, from the lowest: compounds 4, 3, 1 and 2 (each within the scatter of the next).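

In this assay the series now has its first pair that differs in one place only, and the step is a 1.1-fold lower number from compound 3 to compound 4 (0.05 log units; within the scatter) for vinyl in place of 2-hydroxyethyl on a saturated chain carbon bound to an oxygen on an aromatic ring. Among the compounds shown here, at this place, therefore, the hydrogen-bond donor and acceptor of 2-hydroxyethyl can leave and the double bond of vinyl can enter without any difference that this read-out resolves, something the earlier compounds, which differ in more than one place, could not show directly. No measurement at hand accounts for this result.

Compound 3 and compound 4 do not show whether the hydroxyl group or the double bond matters on its own, and a plain propyl group at this place would be needed to separate the two. As far as these compounds go, whether an amine or a carboxylic acid at the end of this chain, or a longer chain ending in a hydroxyl group, would give a step beyond the scatter also remains open.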